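Amino for hydroxy on the core of compound 1

The source may report more compounds than this note shows. Statements on the series, on what has been measured and on what is new or still open speak of the compounds shown alone.

Values in a functional assay on HT-29 cells (Homo sapiens) for inhibition, read by MTT assay, with a stated time of 2 days; a lower number here means a stronger inhibitor, a higher number a weaker inhibitor:
- compound 1 `Oc1ccc(/C=C/c2ccccc2O)cc1`: 22 ug/mL
- compound 2 `Nc1ccccc1/C=C/c1ccc(O)cc1`: > 100 ug/mL (a limit)

In this assay, going by the values given here, compound 1 gives 22 ug/mL, the only actual number so far. Compound 2 stands at > 100 ug/mL, which is a limit of the assay.

Compound 3 `Nc1ccc(/C=C/c2ccccc2O)cc1` is still unmeasured and differs from compound 1 by amino in place of hydroxy on an aromatic carbon. Among the compounds with values here, the one measured step is the same exchange made at the other hydroxy: an at least 4.5-fold higher number from compound 1 to compound 2 (0.65 log units; beyond the scatter). A smaller change in the same direction, towards a higher number, is expected in this assay. The estimated change is a 1.4-fold higher number from compound 1 to compound 3 (0.13 log units; within the scatter). Compound 3 is expected at 30 ug/mL, with an estimated range of 8 ug/mL to 100 ug/mL.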

Compound 3, half-maximal inhibitory concentration: 37 ug/mL
The estimate for compound 3 lay 1.2-fold (0.09 log units) below the measured number; the range from low to high includes it.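

In this assay, amino in place of hydroxy at this position, para to a group of 9 heavy atoms, gives a 1.7-fold higher number from compound 1 to compound 3 (0.23 log units; within the scatter). The same exchange at the other hydroxy gave an at least 4.5-fold higher number from compound 1 to compound 2 (0.65 log units; beyond the scatter), so among these compounds the outcome differs with the place of the exchange. The value of compound 2 is a limit, and the full size of its step stays unknown: the limit of > 100 ug/mL in this assay, at which 1 of the 3 values shown sits.

The compounds shown leave open whether a methoxy group or an acetamide at this position would also stay within the scatter of compound 1. They also leave open what amino at both places would give.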